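The compounds below may be only part of what the source reports. "The series", "measured", "known", "first", "only" and "open" are said of these compounds alone.

In an ADME assay on microsomes from liver (Rattus norvegicus) for metabolic stability (on this read-out higher numbers stand for a longer-lived compound and lower numbers for a shorter-lived compound), compound 1 `N#Cc1ccc(-c2nc(NCCNc3ccc([N+](=O)[O-])c(N)n3)ncc2-c2ncc[nH]2)cc1` is known only as a limit, > 0.5 h. Compound 2 `Nc1nc(NCCNc2ncc(-c3ncc[nH]3)c(-c3ccc(C(F)(F)F)cc3)n2)ccc1[N+](=O)[O-]` also gives only a limit, > 0.5 h. Compound 3 `Nc1nc(NCCNc2ncc(-c3ncc[nH]3)c(-c3ccccc3Br)n2)ccc1[N+](=O)[O-]` likewise gives a limit, > 0.5 h. The whole series therefore sits at the limit of > 0.5 h in this assay, at which 3 of the 3 values shown sit. Compound 4 `Nc1nc(NCCNc2ncc(-c3ncc[nH]3)c(-c3cc(F)ccc3F)n2)ccc1[N+](=O)[O-]` differs from compound 1 in one place: 2,5-difluorophenyl in place of 4-cyanophenyl on an aromatic carbon. The closest measured step is a step that the two limits leave unreadable from compound 1 to compound 3, which replaces the same 4-cyanophenyl. Also relevant are a step that the two limits leave unreadable from compound 1 to compound 2 and a step that the two limits leave unreadable from compound 2 to compound 3. None of these has a readable size, so they give no direction, and no change beyond the scatter is expected in this assay. The expected change is a step that the limit leaves unreadable from compound 1 to compound 4. Compound 4 is expected at 1 h, with an estimated range of 0.5 h to 2.5 h.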

Compound 4, half-life: > 0.5 h
Compound 4: no number, only a limit; the forecaster's own chance of this, stated with the estimate: 85%; the middle value does not contradict the limit.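

Compound 4 gives only a limit in this assay, > 0.5 h. No step to compound 4 from compound 1, compound 2 or compound 3 can be read: the limit of > 0.5 h in this assay, at which 4 of the 4 values shown sit.

As far as these compounds go, whether these four compounds differ in half-life at all stays open.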